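Ethyl in Place of Chloro on the Carbamate Aryl Ring

The source may report more compounds than this note shows. Statements on the series, on what has been measured and on what is new or still open speak of the compounds shown alone.

Compound 1, `C=C1C(=O)OC[C@@H]1CCOC(=O)Nc1ccc(I)cc1`: 790 nM
Compound 2, `C=C1C(=O)OC[C@@H]1CCOC(=O)Nc1ccc(Cl)cc1`: 1070 nM

In a functional assay on RAW264.7 cells (Mus musculus) for inhibition, with a stated time of 30 min (a lower number here means a stronger inhibitor, a higher number a weaker inhibitor), compound 1 gives 790 nM and compound 2 gives 1070 nM. Going by the values given here, compound 2 is one of only two compounds measured, and the single step, a 1.4-fold higher number from compound 1 to compound 2 (0.13 log units; within the scatter), lies within the scatter, so the two stand level and neither can be called the stronger inhibitor.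

Compound 3, `C=C1C(=O)OC[C@@H]1CCOC(=O)Nc1ccc(CC)cc1`, differs from compound 2 by ethyl in place of chloro on an aromatic carbon. Among the compounds with values here, the only measured step, a 1.4-fold higher number from compound 1 to compound 2 (0.13 log units; within the scatter), exchanges one halogen for another at this same aromatic carbon and was within the scatter; no measured step covers an ethyl group. On this basis no step beyond the scatter is expected from compound 2 to compound 3 in this assay, that is, an expected change of a 1.1-fold lower number from compound 2 to compound 3 (0.03 log units; within the scatter). Compound 3 is therefore estimated at 1000 nM, with a range from 400 nM to 2500 nM.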

Compound 3, half-maximal inhibitory concentration: 1260 nM
For compound 3 the middle estimate is 1.3-fold (0.10 log units) below the measured one, within the range that was stated.
By their numbers in this assay, from the lowest: compounds 1, 2 and 3 (each within the scatter of the next).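

In this assay, the step with ethyl in place of chloro on the aromatic carbon para to a large group is a 1.2-fold higher number from compound 2 to compound 3 (0.07 log units; within the scatter) and the step with ethyl in place of iodo is a 1.6-fold higher number from compound 1 to compound 3 (0.20 log units; within the scatter) as well. The position is thus no longer tested with halogens alone: a carbon substituent also stands level with both, and the three compounds cannot be separated in this assay. Nothing available here bears on why these three groups stand level.

On these data alone, whether an amine, a carboxylic acid or a longer chain on this carbon would stay level with these three remains open. So does whether chloro, iodo and ethyl would stand level on another carbon of the ring.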